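Bromo for Chloro: From Compound 3 to Compound 4

The source may report more compounds than this note shows. Statements on the series, on what has been measured and on what is new or still open speak of the compounds shown alone.

Compound 1 `C=C1C(=O)[C@]23C[C@@]1(O)CC[C@H]2c1ccc(OS(=O)(=O)c2ccc(C)cc2)c(C)c1[C@@H]3Cn1cc(-c2ccc(Br)cc2)nn1` gives 4320 nM in a functional assay on SMMC-7721 cells (Homo sapiens) for cytotoxicity, read by MTT assay, with a stated time of 4 days; on this read-out lower numbers stand for stronger inhibition and higher numbers for weaker inhibition.
Compound 2 `C=C1C(=O)[C@]23C[C@@]1(O)CC[C@H]2c1ccc(OS(=O)(=O)c2ccc(C)cc2)c(C)c1[C@@H]3Cn1cc(-c2ccc(Cl)cc2)nn1` gives 6180 nM in this assay.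
Compound 3 `C=C1C[C@]23C[C@@]1(O)CC[C@@H]2c1cccc(C)c1[C@@H]3Cn1cc(-c2ccc(Cl)cc2)nn1` gives > 20000 nM in this assay, which is a limit of the assay and not a number.

Compound 2 and compound 1 differ only by bromo in place of chloro on an aromatic carbon, and that change made a 1.4-fold lower number from compound 2 to compound 1 (0.16 log units; within the scatter). Compound 4 `C=C1C[C@]23C[C@@]1(O)CC[C@@H]2c1cccc(C)c1[C@@H]3Cn1cc(-c2ccc(Br)cc2)nn1` stands to compound 3 as compound 1 stands to compound 2: the change is bromo in place of chloro on an aromatic carbon, the same change at the same place. How the core of compound 3 differs from that of compound 2 is not broken down here. For compound 3 only a limit is known (the limit of > 20000 nM in this assay, at which 1 of the 3 values shown sits). The expected step that the limit leaves unreadable from compound 3 to compound 4 is small. That expectation rests on a 1.4-fold lower number from compound 2 to compound 1 (0.16 log units; within the scatter). Compound 4 is therefore expected near 25000 nM, between 12000 nM and 60000 nM, most likely again reported only as a limit in this assay.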

Compound 4, half-maximal inhibitory concentration: > 20000 nM
Compound 4: a limit, no number; the forecaster's own chance of this, stated with the estimate: 65%; the middle value is on the limit's open side.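

Going by these compounds alone, compound 3 and compound 4 both sit at a limit of the assay rather than at a number, so no step between them can be read: the limit of > 20000 nM in this assay, at which 2 of the 4 values shown sit. As far as these compounds go, whether bromo in place of chloro changes cytotoxicity on their shared core remains open.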